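Moving the Chlorine on the Benzyl Group

This account rests on a few compounds, and the source may have more. Where it says the series, first, only, none or still open, it means among the compounds named here.

Compound 1 `C=C(Br)C(=O)Nc1cccc(/C=C2\SC(=O)N(Cc3ccc(Cl)cc3)C2=O)c1` is the anchor of this small set. Among the measured compounds shown here, in a functional assay on FM3A cells (Mus musculus) for cytotoxicity, read by cell counting, with a stated time of 2 days (a lower number here means a stronger inhibitor, a higher number a weaker inhibitor), compound 1 gives 1600 nM, and this is the only definite number that the set contains. Compound 2 `Nc1cccc(/C=C2\SC(=O)N(Cc3cccc(F)c3)C2=O)c1` reaches only a limit of the assay in this assay, reported as > 250000 nM. That value is the limit of > 250000 nM in this assay, at which 1 of the 2 values shown sits, so it marks an edge of the measurement rather than a number that could be weighed against compound 1.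

Compound 3 `C=C(Br)C(=O)Nc1cccc(/C=C2\SC(=O)N(Cc3cccc(Cl)c3)C2=O)c1` differs from compound 1 in one place: 3-chlorophenyl in place of 4-chlorophenyl on a saturated chain carbon bound to an amide-type nitrogen in a ring. Cut one bond further out, the same change reads 4-chlorobenzyl to 3-chlorobenzyl. For the measured compounds named here, no measured pair in the set follows a move of the chlorine around that ring, so there is no measured step to lean on. He therefore expects no step beyond the usual scatter in this assay. For compound 3 he estimates a value of 1600 nM, within a range from 600 nM to 4500 nM. This estimate means an expected step of no change at the digits printed from compound 1 to compound 3 (within the scatter).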

Compound 3, half-maximal inhibitory concentration: 1700 nM
The estimate for compound 3 lay 1.1-fold (0.03 log units) below the measured number; measured number inside the range.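

In this assay the swap of 4-chlorobenzyl for 3-chlorobenzyl gives a 1.1-fold higher number from compound 1 to compound 3 (0.03 log units; within the scatter) and so leaves compound 1 and compound 3 with no order between them. Among the compounds shown here, this is the first step in the set that can be read, and it shows that, with the rest of compound 1 held fixed, moving the chlorine between these two printed places on the ring makes no difference that this measurement can detect. Nothing given here bears on why the two numbers agree.

Whether that holds for anything other than a moved chlorine remains open, since the compounds shown say nothing about an unsubstituted benzyl group, a methoxy group on the ring or a longer chain in place of the benzyl group. For the compounds shown here, compound 2 gives > 250000 nM, which is a limit of the assay and not a number, and as it differs from compound 1 and compound 3 in more than one place, no step to it can be read.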